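Cytotoxicity notes: cyano for chloro on the aniline ring

The source may report more compounds than this note shows. Statements on the series, on what has been measured and on what is new or still open speak of the compounds shown alone.

Measured compounds:
compound 1 `COc1ccnc(Nc2ccc(Cl)c(OCC=C(C)C)c2)n1`, 9000 nM
compound 2 `CC(C)=CCOc1cc(Nc2nccc(C)n2)ccc1Cl`, 150 nM
compound 3 `CCc1ccnc(Nc2ccc(Cl)c(OCC=C(C)C)c2)n1`, 330 nM

In an ADME assay on MT2 cells (Homo sapiens) for cytotoxicity (on this read-out lower numbers stand for higher toxicity in this test and higher numbers for lower toxicity in this test), compound 1 stands highest of the three numbers, with a 60-fold lower number from compound 1 to compound 2 (1.78 log units; beyond the scatter) and a 27-fold lower number from compound 1 to compound 3 (1.44 log units; beyond the scatter); both replacements on the other ring lowered the number beyond the scatter. Between compound 2 and compound 3 the step was a 2.2-fold higher number from compound 2 to compound 3 (0.34 log units; beyond the scatter).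

Compound 4 `COc1ccnc(Nc2ccc(C#N)c(OCC=C(C)C)c2)n1` differs from compound 1 at another place: cyano in place of chloro on an aromatic carbon. For the measured compounds named here, none of the measured steps touches that ring carbon or the chloro group, so no measured step bears on this change. Without a comparable step the expectation defaults to no change beyond the scatter, with a wide range on either side. Compound 4 is therefore estimated at 8000 nM, between 2500 nM and 25000 nM, which means an expected step of a 1.1-fold lower number from compound 1 to compound 4 (0.05 log units; within the scatter).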

Compound 4, half-maximal cytotoxic concentration: 230 nM
Estimate against measurement, compound 4: 35-fold (1.54 log units) above; the whole stated range lies above it.
By their numbers in this assay, from the lowest: compounds 2, 4 and 3 (each within the scatter of the next, the first and the last beyond it); then compound 1.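

In this assay, the ring carbon ortho to the (3-methylbut-2-en-1-yl)oxy group proves as sensitive as the methoxy site, with cyano in place of chloro giving a 39-fold lower number from compound 1 to compound 4 (1.59 log units; beyond the scatter) and no change at that carbon shown earlier. Compound 4 keeps the methoxy yet falls within the scatter of compounds 2 and 3, so among these four only compound 1, carrying both methoxy and chloro, keeps the high number. Nothing available accounts for this step.

On these data alone, whether cyano acts the same way alongside methyl or ethyl on the other ring remains open. So does whether a bromo or an amine at this carbon tracks chloro or cyano.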